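Chlorinated furan swap on a pyridine-based cytotoxic series

The source may report more compounds than this note shows. Statements on the series, on what has been measured and on what is new or still open speak of the compounds shown alone.

Compound 1, `Cc1ccsc1-c1cc(-c2ccoc2)cc(-c2ccco2)n1`, gives the lowest number of the three measured compounds in a functional assay on HCT-15 cells (Homo sapiens) for cytotoxicity, read by ELISA, with a stated time of 4 days (a higher number here means a weaker inhibitor, a lower number a stronger inhibitor), at 640 nM. Compound 3, `Clc1ccc(-c2cc(-c3ccoc3)cc(-c3ccco3)n2)s1`, gives 1280 nM in this assay, and the step of a 2.0-fold higher number from compound 1 to compound 3 (0.30 log units; within the scatter) lies within the scatter. Among the measured compounds shown here, compound 2, `Cc1ccsc1-c1cc(-c2ccoc2)cc(-c2ccc(Cl)cc2)n1`, gives 2990 nM, and the step of a 4.7-fold higher number from compound 1 to compound 2 (0.67 log units; beyond the scatter) is the only change that clearly weakened inhibition.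

Compound 4, `Cc1ccsc1-c1cc(-c2ccc(Cl)o2)cc(-c2ccco2)n1`, differs from compound 1 by one change: 5-chlorofuran-2-yl in place of furan-3-yl on an aromatic carbon. For the measured compounds named here, no measured step touches the furan-3-yl group itself. The step from compound 1 to compound 3 shows that adding a chlorine to a five-membered ring on the shared core changed little, while the step from compound 1 to compound 2 shows that exchanging one five-membered ring for a chlorinated six-membered ring cost potency. The present change is smaller in kind than the latter, so the expected step of a 1.4-fold higher number from compound 1 to compound 4 (0.15 log units; within the scatter) is small and, if anything, towards a higher number. Compound 4 is therefore estimated at 900 nM, within a range of 400 nM to 2500 nM.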

Compound 4, half-maximal inhibitory concentration: 26300 nM
Beside the measured number, compound 4's estimate is 29-fold (1.47 log units) below it, and the stated range ends below it.
By their numbers in this assay, from the lowest: compounds 1 and 3 (each within the scatter of the next); then compound 2; then compound 4.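

In this assay the exchange of furan-3-yl for 5-chlorofuran-2-yl opposite the ring nitrogen gave a 41-fold higher number from compound 1 to compound 4 (1.61 log units; beyond the scatter) and is the largest step shown, so this place on the shared core responded far more strongly to a change than the earlier steps at other places had. The change combines a different attachment point on the furan with an added chlorine, and this single step cannot separate the two. Nothing available bears on the cause of this step.

The compounds shown leave open whether unsubstituted furan-2-yl at this place, or a chlorine on furan-3-yl, would account for the step. They also leave open how this place would respond to a group of another kind, such as an amine or a carboxylic acid.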